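The compounds below may be only part of what the source reports. "The series", "measured", "known", "first", "only" and "open" are said of these compounds alone.

The three measured compounds in an assay on HEK293 cells for agonist activity at transient receptor potential cation channel subfamily M member 8 (Homo sapiens), read by fluorescence and calcium flux, with a stated time of 15 min; on this read-out higher numbers stand for an effect only at larger amounts of compound and lower numbers for an effect already at smaller amounts:
Compound 1 `CCN(Cc1ccco1)C(=O)COc1ccc(C)cc1` gives 489 nM.
Compound 2 `CCN(Cc1cccs1)C(=O)COc1ccc(CO)cc1` gives 21900 nM.
Compound 3 `Cc1ccc(OCC(=O)N(Cc2cccs2)c2ccncc2)cc1` gives 52 nM.

Among these, compound 1 holds the second highest number: compound 3 sits below it by a margin beyond the scatter, while compound 2 lies far above it, also beyond the scatter. Compound 4 `CCN(C(=O)COc1ccc(C)cc1)C(C)c1cccs1` has not yet been measured. It differs from compound 1 in one place: 1-(thiophen-2-yl)ethyl in place of (furan-2-yl)methyl on an amide-type nitrogen. For the measured compounds named here, no measured pair isolates this change, so any expectation rests only on the three numbers above. In this assay a small step toward a lower number is expected, a 1.6-fold lower number from compound 1 to compound 4 (0.21 log units; within the scatter), one that could still fall within the scatter. Compound 4 is therefore estimated at 300 nM, with a range from 80 nM to 1500 nM.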

Compound 4, half-maximal effective concentration: "not active" (no number reported)
Compound 4 has no reported number here; no gap can be computed for the estimate.
By their numbers in this assay, from the lowest: compound 3; then compound 1; then compound 2.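

Compound 4 carries no number in this assay, only the report "not active", so no step from compound 1 can be read, and no evidence here explains this result. The compounds shown leave open how (furan-2-yl)methyl and 1-(thiophen-2-yl)ethyl compare on otherwise matched compounds.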